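This account rests on a few compounds, and the source may have more. Where it says the series, first, only, none or still open, it means among the compounds named here.

Measured so far:
- compound 1 `COc1cc(-c2nnc3n2NC(c2cccs2)C(C(=O)c2ccc(C)cc2)S3)cc(OC)c1OC` — 28400 nM
- compound 2 `COc1cc(-c2nnc3n2NC(c2cccs2)C(C(=O)c2ccccc2)S3)cc(OC)c1OC` — a limit, > 100000 nM
- compound 3 `COc1cc(-c2nnc3n2NC(c2ccco2)C(C(=O)c2ccccc2)S3)cc(OC)c1OC` — 39800 nM

In a functional assay on MCF7 cells (Homo sapiens) for cytotoxicity, read by MTT assay, with a stated time of 48 h (a higher number here means a weaker inhibitor, a lower number a stronger inhibitor), compound 1 gives 28400 nM. Compound 3 gives 39800 nM in this assay. For compound 2 only a limit is recorded, > 100000 nM. The values of compound 1 and compound 3 sit within the scatter of each other, so no order between them is claimed.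

Two single changes have been measured. The change methyl in place of hydrogen on an aromatic carbon gave the step of an at least 3.5-fold lower number from compound 2 to compound 1 (0.54 log units; beyond the scatter). The change furan-2-yl in place of thiophen-2-yl on a saturated ring carbon gave the step of an at least 2.5-fold lower number from compound 2 to compound 3 (0.40 log units; beyond the scatter). Both steps are lower bounds only, because the limit of > 100000 nM in this assay, at which 1 of the 3 values shown sits, leaves the starting value open.

Compound 4 `COc1cc(-c2nnc3n2NC(c2ccco2)C(C(=O)c2ccc(C)cc2)S3)cc(OC)c1OC` is not yet measured. It differs from compound 3 by methyl in place of hydrogen on an aromatic carbon, which is the same change as that from compound 2 to compound 1; the place is described in the same words for both. The two cores differ by furan-2-yl in place of thiophen-2-yl on a saturated ring carbon.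

The step expected from compound 3 to compound 4 is a 2.0-fold lower number from compound 3 to compound 4 (0.30 log units; within the scatter), a smaller step than the earlier one is allowed to be, since the earlier step rests on compound 2 and its limit > 100000 nM and its true size is not fixed. For compound 4 the estimated value in this assay is 20000 nM, expected to lie between 8000 nM and 60000 nM.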

Compound 4, half-maximal inhibitory concentration: > 100000 nM
Compound 4 gave a limit, no number; the forecaster's own chance of this, stated with the estimate: 12%; at least 5.0-fold (0.69 log units) between middle value and limit.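

In this assay, methyl in place of hydrogen on an aromatic carbon does not carry from the thiophen-2-yl core to the furan-2-yl core, where it gives an at least 2.5-fold higher number from compound 3 to compound 4 (0.40 log units; beyond the scatter), against the opposite direction on the other core: the same change on two cores in this assay, an at least 3.5-fold lower number (0.54 log units; beyond the scatter) from compound 2 to compound 1 and an at least 2.5-fold higher number (0.40 log units; beyond the scatter) from compound 3 to compound 4, at least 8.8-fold (0.94 log units) apart, beyond the scatter of two such steps. Furan-2-yl in place of thiophen-2-yl on a saturated ring carbon likewise depends on the benzoyl partner, giving an at least 3.5-fold higher number from compound 1 to compound 4 (0.54 log units; beyond the scatter) when the (4-methylphenyl)carbonyl group is present, so neither change can be treated as independent of the other in these four compounds: the same change on two cores in this assay, an at least 2.5-fold lower number (0.40 log units; beyond the scatter) from compound 2 to compound 3 and an at least 3.5-fold higher number (0.54 log units; beyond the scatter) from compound 1 to compound 4, at least 8.8-fold (0.94 log units) apart, beyond the scatter of two such steps. On these data alone, compound 4 gives a limit, > 100000 nM, not a number, so the true step sizes stay open, and the data show that the two changes interact without showing why or whether this extends beyond these compounds: the limit of > 100000 nM in this assay, at which 2 of the 4 values shown sit.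

The compounds shown leave open how an ethyl or methoxy group in place of the methyl would read on the thiophen-2-yl and furan-2-yl cores. They also leave open whether a phenyl ring on the saturated ring carbon would follow either core, and where compound 2 and compound 4 truly stand.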